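Trimming the amine on a thiocarbonyl carbon

This account rests on a few compounds, and the source may have more. Where it says the series, first, only, none or still open, it means among the compounds named here.

Two measured compounds share one core and differ only in the amine attached to a thiocarbonyl carbon; both were tested in a functional assay on MCF7 cells (Homo sapiens) for antiproliferative activity, read by MTT assay, with a stated time of 72 h; a lower number here means a stronger inhibitor, a higher number a weaker inhibitor. Compound 1 `O=c1cc(CSC(=S)N2CCCC2)oc2cc(Cl)ccc12` bears a pyrrolidin-1-yl group there. In this assay compound 1 gives > 25000 nM, which is a limit of the assay rather than a number. Compound 2 `CC(C)N(C(=S)SCc1cc(=O)c2ccc(Cl)cc2o1)C(C)C` carries a diisopropylamino group instead. In this assay compound 2 gives > 25000 nM, again a limit and not a number. The step that the two limits leave unreadable from compound 1 to compound 2 cannot be read, because of the limit of > 25000 nM in this assay, at which 2 of the 2 values shown sit. Compound 3 `CCN(CC)C(=S)SCc1cc(=O)c2ccc(Cl)cc2o1` differs from compound 2 by a single change: diethylamino in place of diisopropylamino on a thiocarbonyl carbon. Going by the values given here, no measured step bears directly on this change, and the only step among the measured compounds, which also swaps the amine on the thiocarbonyl carbon, is unreadable. There is thus no basis for expecting a step beyond the scatter in either direction, and the shared limit suggests that compound 3 will also sit at it. Compound 3 is expected to give 30000 nM, with a range from 8000 nM to 100000 nM. The step this estimate implies, a step that the limit leaves unreadable from compound 2 to compound 3, is expected to be none beyond the scatter.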

Compound 3, half-maximal inhibitory concentration: > 25000 nM
Compound 3: no number, only a limit (the forecaster's own chance of this, stated with the estimate: 75%); the middle value does not contradict the limit.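

Going by these compounds alone, compound 3 also gives only a limit of the assay and not a number, and no step among compound 1, compound 2 and compound 3 can be read: the limit of > 25000 nM in this assay, at which 3 of the 3 values shown sit. The compounds shown leave open whether changing the amine on the thiocarbonyl carbon can shift the result at all in this assay.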